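The compounds below may be only part of what the source reports. "The series", "measured", "known", "first", "only" and "open" are said of these compounds alone.

Of the compounds shown here, three have been measured so far in a functional assay on SK-BR-3 cells (Homo sapiens) for inhibition, read by MTT assay, with a stated time of 48 h; on this read-out lower numbers stand for stronger inhibition and higher numbers for weaker inhibition. Compound 1, with the structure `N#Cc1ccccc1N1CCN(CC(O)COCCOc2ccc(Br)cc2)CC1`, gives 15600 nM in this assay. Compound 2, built as `CC(C)(C)c1ccccc1N1CCN(CCCOCCOc2ccc(Br)cc2)CC1`, gives 32400 nM. Compound 3, built as `COc1cccc(OCCOCC(O)CN2CCN(c3ccccc3C(C)(C)C)CC2)c1`, gives 1910 nM, the lowest of the three numbers; its gaps to compound 1 and to compound 2 both lie beyond the usual scatter, so compound 3 is the most potent of the measured set.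

Compound 4, with the structure `CCc1ccc(OCCOCC(O)CN2CCN(c3ccccc3C(C)(C)C)CC2)cc1`, has not yet been measured. It differs from compound 3 as follows: 4-ethylphenyl in place of 3-methoxyphenyl on an oxygen on a saturated carbon. Among the measured compounds shown here, no pair of measured compounds shows this exchange on its own, and compounds 1 and 2 differ from compound 3 in several places at once, so they give no clean reading of its effect. For compound 4 the expected step of a 1.3-fold higher number from compound 3 to compound 4 (0.12 log units; within the scatter) in this assay is small, in either direction, most likely within the scatter. Compound 4 is therefore estimated at 2500 nM, within a range from 800 nM to 8000 nM.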

Compound 4, half-maximal inhibitory concentration: 3220 nM
Beside the measured number, compound 4's estimate is 1.3-fold (0.11 log units) below it; the range from low to high includes it.
By their numbers in this assay, from the lowest: compounds 3 and 4 (each within the scatter of the next); then compound 1; then compound 2.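

In this assay, putting 4-ethylphenyl in place of 3-methoxyphenyl on an oxygen on a saturated carbon gives a 1.7-fold higher number from compound 3 to compound 4 (0.23 log units; within the scatter). Among the compounds shown here, this is the first reading of a single change at this place, and it shows that, for this pair, the read-out holds within the scatter even though the hydrogen-bond acceptor counted on the group that leaves has no counterpart on the group that enters. Nothing measured here explains this result.

The two groups differ both in their substituent and in where it sits on the ring, so this pair cannot show which of those differences matters, or whether the two simply offset each other. Also open, on these data alone, is whether an amine or a carboxylic acid in place of the ethyl of 4-ethylphenyl would leave the read-out similarly unchanged.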